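A few compounds are considered here, and "the series" means these few. Any claim that something is new, unique, unknown or untested is made for them only; others in the source may bear on it.

Working notes on the series. In a functional assay on KB cells (Homo sapiens) for inhibition, read by MTT assay, with a stated time of 24 h, tested at 1 ug/mL (a higher number here means more inhibition of growth at the concentration tested, a lower number less inhibition of growth), compound 1 (`O=C(CCCCC1CCSS1)NO`) gives 2.57% and compound 2 (`O=C(CCCCC(S)CCS)NO`) gives 10.6%, two values that lie within the scatter of each other. In this assay, compound 3 (`O=C(CCCCC1CCSS1)Nc1ccccn1`) is reported as "not active" (no number reported). It therefore has no single number, and its standing against compound 1 and compound 2 is known only from that wording.

Compound 4 (`O=C(CCCCC1CCSS1)Nc1ccc(Cl)cn1`) differs from compound 3 in one place: chloro in place of hydrogen on an aromatic carbon. This is chloro in place of hydrogen on an aromatic carbon, two atoms from the ring nitrogen and para to a large group. Among the measured compounds shown here, no measured pair tests this change, so the data give no direct size for it.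

In this assay, the step from compound 3 is expected to stay within the scatter, with at most a small upward drift in the read-out. This expectation rests on compound 3 at "not active" (no number reported) and on the low reading of compound 1 at 2.57%. A report without a number remains a real possibility. Compound 4 is estimated at 6%, with an expected range of 0% to 22%.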

Compound 4, percent growth inhibition at one concentration: 0.76%
The estimate for compound 4 lay 5.2 percentage points above the measured number; the range from low to high includes it.
By their numbers in this assay, from the lowest: compounds 4, 1 and 2 (each within the scatter of the next).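

In this assay, among the compounds shown here, compound 3 carries no number while compound 4 gives 0.76%, so no step between compound 3 and compound 4 can be read. No measurement shown bears on this result. The compounds shown leave open what size, if any, the change from hydrogen to chloro has on growth inhibition.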